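A few compounds are considered here, and "the series" means these few. Any claim that something is new, unique, unknown or untested is made for them only; others in the source may bear on it.

Measured in a functional assay on HEK293 cells for positive allosteric modulation of metabotropic glutamate receptor 5 (Homo sapiens), read by FLIPR and calcium flux; on this read-out lower numbers stand for an effect already at smaller amounts and higher numbers for an effect only at larger amounts of compound:
compound 1 `O=C(COCc1ccccc1)N1CCN(c2ccc(Cl)cc2)CC1` gives 350 nM
compound 2 `O=C(COCc1ccccc1)N1CCN(c2ccc(F)cc2)CC1` gives 1100 nM
compound 3 `O=C(COCc1ccccc1)N1CCN(c2ccc(F)cc2F)CC1` gives 300 nM

The cores of compound 2 and compound 3 differ by fluoro in place of hydrogen on an aromatic carbon, and this gives a 3.7-fold lower number from compound 2 to compound 3 (0.56 log units; beyond the scatter). Compound 1 and compound 3 lie close, with a 1.2-fold lower number from compound 1 to compound 3 (0.07 log units; within the scatter). Compound 4 `O=C(COCc1ccccc1)N1CCN(c2ccc(F)cc2Cl)CC1` has not yet been measured in this assay; it differs from compound 3 by chloro in place of fluoro on an aromatic carbon. The same kind of change was made from compound 2 to compound 1, (chloro in place of fluoro on an aromatic carbon), where it gave a 3.1-fold lower number from compound 2 to compound 1 (0.50 log units; beyond the scatter). The places are not the same: from compound 2 to compound 1 the change sits para to a large group, whereas from compound 3 to compound 4 it sits ortho to a large group and meta to a fluoro group. Resting on a 3.1-fold lower number from compound 2 to compound 1 (0.50 log units; beyond the scatter), a step of about a 2.0-fold lower number from compound 3 to compound 4 (0.30 log units; within the scatter) is expected from compound 3 to compound 4. The range is held wide; the two places are not the same. Compound 4 is therefore estimated at 150 nM in this assay.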

Compound 4, half-maximal effective concentration: 270 nM
The estimate for compound 4 lay 1.8-fold (0.26 log units) below the measured number; the measured number falls inside the stated range.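

Chloro in place of fluoro does not carry over in size from one core to the other in this pair: the same change on two cores in this assay, a 3.1-fold lower number (0.50 log units; beyond the scatter) from compound 2 to compound 1 and a 1.1-fold lower number (0.05 log units; within the scatter) from compound 3 to compound 4, 2.8-fold (0.45 log units) apart, beyond the scatter of two such steps

The new step reads a 1.1-fold lower number from compound 3 to compound 4 (0.05 log units; within the scatter). Beside it, the exchange of the aryl groups reads a 1.3-fold lower number from compound 1 to compound 4 (0.11 log units; within the scatter), and chloro in place of hydrogen gives a 4.1-fold lower number from compound 2 to compound 4 (0.61 log units; beyond the scatter). With a single pair on each core, this does not show whether the place of the change or the other groups on the aromatic ring set the gap, and it gives no rule for further cores.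

Open, as far as these compounds go, is whether a methyl, a methoxy or a nitrile at the chloro position would follow either step. Also open, from the compounds shown here alone, is how any change elsewhere on the shared core would behave.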